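The compounds below may be only part of what the source reports. "The series", "measured", "known", "first", "only" and "open" are said of these compounds alone.

Compounds measured:
Compound 1, `CC#C[C@H]1CN(S(=O)(=O)c2ccc(N)nc2)CCN1c1ccc(S(=O)(=NC)C(F)(F)F)cc1`: 2060 nM
Compound 2, `CC#C[C@H]1CN(S(=O)(=O)c2ccc(N)nc2)CCN1c1ccc(S(C)(=N)=O)cc1`: 704 nM

In an assay on cells (Hepatocyte) for inhibition of glucokinase regulatory protein (Mus musculus), with stated times of 20 min and 40 min (a higher number here means that more compound is needed for the effect, a lower number that less compound is needed), compound 2 gives the lowest of the two numbers; the nearest is compound 1 at 2060 nM, and the step of a 2.9-fold lower number from compound 1 to compound 2 (0.47 log units; beyond the scatter) lies beyond the scatter. Compound 3, `CC#C[C@H]1CN(S(=O)(=O)c2ccc(N)nc2)CCN1c1ccc(S(=N)(=O)C2CC2)cc1`, has not yet been measured in this assay. It differs from compound 2 by cyclopropyl in place of methyl on a sulfinyl sulfur.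

Among the compounds with values here, only one measured step exists here, and it concerns a different exchange: the step of a 2.9-fold lower number from compound 1 to compound 2 (0.47 log units; beyond the scatter) replaced a larger group by a smaller one on the same sulfur, and lowered the number modestly. No measured pair shows what happens when methyl on that sulfinyl sulfur is exchanged for cyclopropyl, so the shown data give no direct guide. The expectation for compound 3 is therefore a number near that of compound 2, without a step beyond the scatter; compound 3 is estimated at 700 nM, within a range of 250 nM to 2000 nM. This estimate corresponds to the step of a 1.0-fold lower number from compound 2 to compound 3 (0.00 log units; within the scatter), which is expected to lie within the usual scatter.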

Compound 3, half-maximal effective concentration: 208 nM
Beside the measured number, compound 3's estimate is 3.4-fold (0.53 log units) above it, and the stated range ends above it.
By their numbers in this assay, from the lowest: compound 3; then compound 2; then compound 1.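

In this assay, cyclopropyl in place of methyl on a sulfinyl sulfur gives a 3.4-fold lower number from compound 2 to compound 3 (0.53 log units; beyond the scatter) and shows that this position responds to a change in the carbon group alone, with the sulfur and its other neighbours left as they are. The earlier step went to a group with fewer heavy atoms and lowered the number, whereas here the group with more heavy atoms gives the lower number, so across these compounds the heavy-atom count does not set the direction of change. The whole exchange on the aromatic carbon amounts to a 9.9-fold lower number from compound 1 to compound 3 (1.00 log units; beyond the scatter) and leaves compound 3 with the lowest number of the three, while nothing shown gives a reason for this result.

The compounds shown leave open whether the ring itself or the added carbons account for the step, which an ethyl or isopropyl group on the same sulfur would help to separate, and whether a cyclobutyl group would lower the number further. They also leave open whether the gain from cyclopropyl would hold if the rest of the shared core were changed.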